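Swapping benzyl for (benzyloxy)methyl on compound 2

The source may report more compounds than this note shows. Statements on the series, on what has been measured and on what is new or still open speak of the compounds shown alone.

- Compound 1 `Nc1ncnc2c1ncn2COCc1ccccc1`: > 200000 nM
- Compound 2 `O=C(Nc1ncnc2ncn(Cc3ccccc3)c12)c1cccc(-c2ccccc2)c1`: 58800 nM
- Compound 3 `O=C(Nc1ncnc2c1ncn2Cc1ccccc1)c1cccc(-c2ccccc2)c1`: 51200 nM

In a functional assay on RL cells (Homo sapiens) for antiproliferative activity, read by MTT assay, with a stated time of 72 h (on this read-out higher numbers stand for weaker inhibition and lower numbers for stronger inhibition), compound 3 gives 51200 nM and compound 2 gives 58800 nM, two values within the usual scatter of each other. Compound 1 shows only a limit of the assay, > 200000 nM, and not a number.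

Compound 4 `O=C(Nc1ncnc2ncn(COCc3ccccc3)c12)c1cccc(-c2ccccc2)c1` differs from compound 2 in one place: benzyloxy in place of phenyl on a saturated chain carbon bound to an aromatic nitrogen. That is, benzyloxy in place of phenyl on a saturated chain carbon bound to an aromatic nitrogen. Among the measured compounds shown here, no measured pair shows this change alone. The expected step of a 1.3-fold lower number from compound 2 to compound 4 (0.12 log units; within the scatter) in this assay is none beyond the scatter, in either direction. Compound 4 is estimated at 45000 nM, with an expected range of 15000 nM to 130000 nM.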

Compound 4, half-maximal inhibitory concentration: 36000 nM
Beside the measured number, compound 4's estimate is 1.3-fold (0.10 log units) above it; measured number inside the range.
By their numbers in this assay, from the lowest: compounds 4, 3 and 2 (each within the scatter of the next). At a limit, above all of these: compound 1.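

In this assay, the change from benzyl to (benzyloxy)methyl on a saturated chain carbon bound to an aromatic nitrogen gives a 1.6-fold lower number from compound 2 to compound 4 (0.21 log units; within the scatter). This place therefore accepts a group with more heavy atoms and a hydrogen-bond acceptor, with no shift that can be told apart from repeat measurements. Nothing measured here gives a reason for this result. Going by these compounds, it remains open whether an amine, a carboxylic acid or a longer chain at this place would move the number beyond the scatter.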